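Halogen position and potency in a carboxyphenyl ether series

The compounds below may be only part of what the source reports. "The series", "measured", "known", "first", "only" and "open" are said of these compounds alone.

Compound 1 `Cc1c(OC[C@@H](C)COc2ccc(Cl)c(C(=O)O)c2)ccc(C(=O)CC(C)(C)C)c1O`: 377 nM
Compound 2 `Cc1c(OC[C@@H](C)COc2ccc(C(=O)O)cc2F)ccc(C(=O)CC(C)(C)C)c1O`: 222 nM
Compound 3 `Cc1c(OC[C@@H](C)COc2ccc(C(=O)O)cc2Cl)ccc(C(=O)CC(C)(C)C)c1O`: 477 nM

Three compounds sharing one core have been examined in an assay for positive allosteric modulation of metabotropic glutamate receptor 2 (Rattus norvegicus); a higher number here means that more compound is needed for the effect, a lower number that less compound is needed. Compound 3 gives 477 nM, the highest of the three numbers; its nearest neighbour is compound 1, at 377 nM, and the two differ by a 1.3-fold higher number from compound 1 to compound 3 (0.10 log units; within the scatter). Compound 2, at 222 nM, sits furthest from it, the gap being a 2.1-fold higher number from compound 2 to compound 3 (0.33 log units; beyond the scatter).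

Compound 4 `Cc1c(OC[C@@H](C)COc2ccc(C(=O)O)c(F)c2)ccc(C(=O)CC(C)(C)C)c1O` has not yet been measured. It differs from compound 3 in one place: 4-carboxy-3-fluorophenyl in place of 4-carboxy-2-chlorophenyl on an oxygen on a saturated carbon. Two of the measured steps bear on this. The swap of chloro for fluoro on the aromatic carbon gave a 2.1-fold higher number from compound 2 to compound 3 (0.33 log units; beyond the scatter), a modest step beyond the scatter, and the move of the carboxy group around the ring gave a 1.7-fold lower number from compound 1 to compound 2 (0.23 log units; within the scatter), within the scatter. Going by the values given here, no measured pair shows the halogen moved to the position it takes in compound 4, so the expectation rests on the halogen swap alone. Compound 4 is therefore expected to give a somewhat lower number than compound 3, a step of about a 1.6-fold lower number from compound 3 to compound 4 (0.20 log units; within the scatter) in this assay, though the shifted position leaves the range wide. The estimate for compound 4 is 300 nM, between 150 nM and 600 nM.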

Compound 4, half-maximal effective concentration: 261 nM
Compound 4: the middle estimate sits 1.1-fold (0.06 log units) above what was measured; low and high end bracket the measured number.
By their numbers in this assay, from the lowest: compounds 2, 4, 1 and 3 (each within the scatter of the next, the first and the last beyond it).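

In this assay, compound 4 gives the first view of a halogen moved while the carboxy group stays in place, and this change, 4-carboxy-3-fluorophenyl in place of 4-carboxy-2-fluorophenyl, stays within the scatter (a 1.2-fold higher number from compound 2 to compound 4 (0.07 log units; within the scatter)). Compound 2 stood beyond the scatter from compound 3 (a 2.1-fold higher number from compound 2 to compound 3 (0.33 log units; beyond the scatter)), but compound 4 does not (a 1.8-fold lower number from compound 3 to compound 4 (0.26 log units; within the scatter)), so that gap does not hold for both fluoro compounds. Compound 4 also lies within the scatter of compound 1 (a 1.4-fold lower number from compound 1 to compound 4 (0.16 log units; within the scatter)), so compounds 1, 2 and 4 cannot be told apart here.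

From the compounds shown here alone, it remains open whether 4-carboxy-3-chlorophenyl, a methyl or methoxy group in place of the halogen, or an amide in place of the carboxylic acid would shift the number. Nothing shown here explains any of these steps.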